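Thiophen-3-yl in place of benzofuran-2-yl on two cores

The compounds below may be only part of what the source reports. "The series", "measured", "known", "first", "only" and "open" are said of these compounds alone.

Compound 1 `O=c1[nH]cnc2c1c(-c1ccsc1)cn2[C@@H]1O[C@H](CO)[C@@H](O)[C@H]1O` and compound 2 `O=c1[nH]cnc2c1c(-c1cc3ccccc3o1)cn2[C@@H]1O[C@H](CO)[C@@H](O)[C@H]1O` share one core and differ in a single place: thiophen-3-yl in place of 1-benzofuran-2-yl on an aromatic carbon. In a functional assay on K562 cells (Homo sapiens), read by MTT assay, with a stated time of 72 h (a lower number here means a stronger inhibitor, a higher number a weaker inhibitor), compound 1 reaches only the assay limit of > 20000 nM. In this assay compound 2 likewise reaches only the limit of > 20000 nM. The step that the two limits leave unreadable from compound 2 to compound 1 cannot be sized because of the limit of > 20000 nM in this assay, at which 2 of the 3 values shown sit. Compound 3 `Cc1nc(N)c2c(-c3cc4ccccc4o3)cn([C@@H]3O[C@H](CO)[C@@H](O)[C@H]3O)c2n1` carries the same 1-benzofuran-2-yl group on a second core; the difference between the two cores is not broken down here. In this assay, among the compounds with values here, compound 3 gives 4990 nM, the only true number among the three values. Compound 4 `Cc1nc(N)c2c(-c3ccsc3)cn([C@@H]3O[C@H](CO)[C@@H](O)[C@H]3O)c2n1` has not yet been measured; it differs from compound 3 by the same change, (thiophen-3-yl in place of 1-benzofuran-2-yl on an aromatic carbon), at a place described identically. The earlier step gives no readable size, so the expectation rests on compound 3 at 4990 nM and on what compound 1 and compound 2 showed on the first core. The step from compound 3 to compound 4 is expected to be a 2.4-fold higher number from compound 3 to compound 4 (0.38 log units; beyond the scatter), a loss that may again end at the limit. Compound 4 is estimated to give 12000 nM, between 4000 nM and 40000 nM.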

Compound 4, half-maximal inhibitory concentration: > 20000 nM
Compound 4 gave a limit, no number; the forecaster's own chance of this, stated with the estimate: 50%; middle value at least 1.6-fold (0.22 log units) away from the limit.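

In this assay compound 4 gives > 20000 nM, which is a limit of the assay and not a number. Even so, the change can be sized in one direction on this core, as an at least 4.0-fold higher number from compound 3 to compound 4 (0.60 log units; beyond the scatter), so thiophen-3-yl in place of 1-benzofuran-2-yl goes with a loss on the core of compound 3, and the full size of that loss stays unknown. The same step on the core of compound 1 cannot be read, so the series does not show whether the change has the same size on both cores, nor whether the loss seen with compound 4 carries over, because so many values end in the same place: the limit of > 20000 nM in this assay, at which 3 of the 4 values shown sit.

The compounds shown leave open which part of the difference between the two cores lets compound 3 give a number at all. They also leave open whether an amine or a carboxylic acid on a longer chain, set on the same aromatic carbon in place of 1-benzofuran-2-yl, would keep or lose that activity.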